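The source may report more compounds than this note shows. Statements on the series, on what has been measured and on what is new or still open speak of the compounds shown alone.

Measured compounds:
- compound 1, `Nc1sc(-c2ccc(Cl)cc2)c(-c2ccc(Cl)cc2)c1C(=O)N1CCCCC1=O`: 1820 nM
- compound 2, `CC1CCN(C(=O)c2c(N)sc(-c3ccc(Cl)cc3)c2-c2ccc(Cl)cc2)CC1`: 1750 nM

Both were tested in a functional assay on A549 cells (Homo sapiens) for inhibition, read by sulforhodamine B assay, with a stated time of 72 h; on this read-out lower numbers stand for stronger inhibition and higher numbers for weaker inhibition. On these two numbers compound 1 stands highest, with compound 2 nearest; the step of a 1.0-fold lower number from compound 1 to compound 2 (0.02 log units; within the scatter) is within the scatter, so the two cannot be ordered.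

Compound 3, `Nc1sc(-c2ccc(Cl)cc2)c(-c2ccc(Cl)cc2)c1C(=O)Nc1ccccc1`, is not yet measured. It differs from compound 1 in one place: anilino in place of 2-oxopiperidin-1-yl on a carbonyl carbon. For the measured compounds named here, the only measured step that bears on this is the one from compound 1 to compound 2, which also exchanges the group on the same carbonyl carbon and produced no shift beyond the scatter. With only that to go on, no step beyond the scatter is expected in this assay for the change to anilino either. Compound 3 is therefore expected to give about 1800 nM, within a range of 600 nM to 5500 nM, which means an expected step of a 1.0-fold lower number from compound 1 to compound 3 (0.00 log units; within the scatter).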

Compound 3, half-maximal inhibitory concentration: 25000 nM
Estimate against measurement, compound 3: 14-fold (1.14 log units) below, outside the stated range (above it).
By their numbers in this assay, from the lowest: compounds 2 and 1 (each within the scatter of the next); then compound 3.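

In this assay the group on this carbonyl carbon turns out to matter: the change to anilino gives a 14-fold higher number from compound 1 to compound 3 (1.14 log units; beyond the scatter) and, starting from the other measured amide, gives a 14-fold higher number from compound 2 to compound 3 (1.15 log units; beyond the scatter). Anilino and 2-oxopiperidin-1-yl have the same count of heavy atoms, so that count does not separate them; what differs is an aromatic ring of carbon only in place of a non-aromatic ring, and a hydrogen-bond donor in place of a hydrogen-bond acceptor. No measurement at hand explains this step.

The compounds shown leave open whether the aromatic ring or the amide hydrogen goes with the higher number. A cyclohexylamino group, which keeps that hydrogen but carries a non-aromatic ring, would separate the two.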